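Lengthening the linker to the sulfamoylamino group

The compounds below may be only part of what the source reports. "The series", "measured", "known", "first", "only" and "open" are said of these compounds alone.

Measured compounds:
compound 1 `Cc1ccc(-c2cc(N3CCC(CNS(N)(=O)=O)CC3)ncn2)cc1`, 33900 nM
compound 2 `CCCCc1ccc(-c2cc(N3CCC(CNS(N)(=O)=O)CC3)ncn2)cc1`, 15200 nM
compound 3 `NS(=O)(=O)NCC1CCN(c2cc(-c3ccc(C(F)(F)F)cc3)ncn2)CC1`, 29100 nM

In a functional assay on HT-29 cells (Homo sapiens) for antiproliferative activity, read by sulforhodamine B assay, with a stated time of 48 h (on this read-out lower numbers stand for stronger inhibition of growth and higher numbers for weaker inhibition of growth), compound 2 gives the lowest number of the three. Compound 3 sits within the scatter of it, as a 1.9-fold higher number from compound 2 to compound 3 (0.28 log units; within the scatter) shows, while compound 1 stands beyond it: a 2.2-fold lower number from compound 1 to compound 2 (0.35 log units; beyond the scatter). Compound 1 and compound 3 differ from each other only within the scatter, a 1.2-fold lower number from compound 1 to compound 3 (0.07 log units; within the scatter).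

Compound 4 `CCCCc1ccc(-c2cc(N3CCC(CCNS(N)(=O)=O)CC3)ncn2)cc1` keeps the butyl-bearing aryl group of compound 2 and changes the other end: (sulfamoylamino)methyl in place of sulfamoylamino on a saturated chain carbon bound to a saturated ring carbon. Among the measured compounds shown here, none of the measured steps touches this part of the molecule; all three concern the group on the aromatic ring. So there is no measured step that bears on this change, and the expectation for this assay rests only on the fact that the rest of the structure is kept. The expected step is small, with no direction beyond the scatter: a 1.0-fold lower number from compound 2 to compound 4 (0.01 log units; within the scatter). Compound 4 is therefore estimated at 15000 nM, within a range from 6000 nM to 40000 nM.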

Compound 4, concentration for 50% growth inhibition: 13300 nM
Estimate against measurement, compound 4: 1.1-fold (0.05 log units) above; measured number inside the range.
By their numbers in this assay, from the lowest: compounds 4, 2, 3 and 1 (each within the scatter of the next, the first and the last beyond it).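

Among the compounds shown here, compound 4 gives the first reading on the linker end of the molecule, where all earlier steps concerned the group on the aromatic ring. In this assay, the added carbon on a saturated chain carbon bound to a saturated ring carbon gives a 1.1-fold lower number from compound 2 to compound 4 (0.06 log units; within the scatter), so the two compounds cannot be told apart and this linker length can change by that one carbon without a measurable shift in growth inhibition. No measurement is available that would explain this result.

The compounds shown leave open whether a longer chain, such as 3-(sulfamoylamino)propyl, or a different end group, such as an amine or a carboxylic acid in place of sulfamoylamino, would also stay within the scatter. Going by these compounds, it also remains open whether the same added carbon would behave alike with the methyl of compound 1 or the trifluoromethyl of compound 3 on the aromatic ring.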